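Swapping Chloro for Iodo on a Shifted Core

The source may hold more compounds than are shown below. What is called first, only, known or untested is meant among the compounds shown, and "the series" means these compounds.

Of the compounds shown here, three have been tested in a functional assay on OVCAR-4 cells (Homo sapiens) for inhibition; on this read-out lower numbers stand for stronger inhibition of growth and higher numbers for weaker inhibition of growth. Compound 1 `Nc1ccc(-c2nc3ccc(F)cc3s2)cc1I` gives 30 nM in this assay. Compound 2 `Nc1ccc(-c2nc3ccc(F)cc3s2)cc1Cl` gives 20 nM. Compound 3 `Nc1ccc(-c2nc3cc(F)ccc3s2)cc1Cl` gives 320 nM, the highest of the three numbers, so its growth inhibition is the weakest among them.

Compounds 1 and 2 differ in one place: iodo in place of chloro on an aromatic carbon. That change produced a 1.5-fold higher number from compound 2 to compound 1 (0.18 log units; within the scatter), a step that does not stand out from the ordinary variation of such measurements.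

Compound 3 is built from the same atoms as compound 2, joined differently; the difference between the two cores is not broken down here. Whatever that rearrangement does, the values of compound 2 and compound 3 show a clear rise in the number.

Compound 4 `Nc1ccc(-c2nc3cc(F)ccc3s2)cc1I` has not yet been measured. It relates to compound 3 exactly as compound 1 relates to compound 2: iodo in place of chloro on an aromatic carbon, at the same place on the ring. Among the measured compounds shown here, because the only measured example of this change, a 1.5-fold higher number from compound 2 to compound 1 (0.18 log units; within the scatter), stayed within the scatter, the expectation is that compound 4 will likewise sit close to compound 3, with an estimated step of a 1.4-fold higher number from compound 3 to compound 4 (0.15 log units; within the scatter). On that basis, compound 4 is estimated at 450 nM, expected to fall between 200 nM and 1200 nM.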

Compound 4, concentration for 50% growth inhibition: < 10 nM
Compound 4 was reported as a limit; the forecaster's own chance of this, stated with the estimate: 3%; at least 45-fold (1.65 log units) between middle value and limit.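

On the core of compound 3, the same swap of chloro for iodo gave an at least 32-fold lower number from compound 3 to compound 4 (1.50 log units; beyond the scatter), so in this assay the result seen on the core of compound 2 did not carry over to the second core: the same change on two cores in this assay, a 1.5-fold higher number (0.18 log units; within the scatter) from compound 2 to compound 1 and an at least 32-fold lower number (1.50 log units; beyond the scatter) from compound 3 to compound 4, at least 48-fold (1.68 log units) apart, beyond the scatter of two such steps

In the same assay, compound 4 gives < 10 nM, which is a limit and not a number: the limit of < 10 nM in this assay, at which 1 of the 4 values shown sits.

These two pairs show that, within this small set, the outcome of the swap depends on the core it is made on, so the near absence of change from compound 2 to compound 1 was a poor guide to compound 4; they do not show why the two cores part ways, and two examples cannot say what the swap would do on any third core.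

The compounds shown leave open whether this sharp gain in growth inhibition belongs to iodo alone or would also appear with bromo, or with a non-halogen group such as methyl or a nitrile, in the same place. On these data alone, it also remains open whether the amino group is needed for the effect, which a comparison with a matching compound carrying a hydroxyl or an acetamide group in its place could begin to test.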